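The source may hold more compounds than are shown below. What is called first, only, known or untested is meant among the compounds shown, and "the series" means these compounds.

Measured so far in an ADME assay on HepG2 2.2.15 cells (Homo sapiens) for cytotoxicity; a higher number here means that more compound is tolerated, a lower number that less compound is tolerated:
compound 1 `Cn1c(=O)c(CCO)c(-c2ccccc2Cl)c2cc(Cl)ccc21`: 34000 nM
compound 2 `O=c1c(CCO)c(-c2ccccc2Cl)c2cc(Cl)ccc2n1-c1ccccc1`: 26000 nM
compound 3 `N#CCC(=O)OCCc1c(-c2ccccc2Cl)c2cc(Cl)ccc2[nH]c1=O`: 100000 nM

Compound 3 holds the highest of the three numbers: compound 1 lies nearest, compound 2 furthest, and both gaps are beyond the scatter, so compound 3 is the best tolerated of the set. Among the measured compounds shown here, the only step between measured compounds, a 1.3-fold lower number from compound 1 to compound 2 (0.12 log units; within the scatter), lies within the scatter and concerns the aromatic nitrogen, which is not the place altered here.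

Compound 4 `O=C(OCCc1c(-c2ccccc2Cl)c2cc(Cl)ccc2[nH]c1=O)c1cccnc1` differs from compound 3 by pyridin-3-yl in place of cyanomethyl on a carbonyl carbon. For the measured compounds named here, no measured step touches the carbonyl carbon of the ester, so nothing among the three compounds bears directly on this change; the only guide is that compound 3 itself sits at the high end. The expectation is therefore a step close to none, with a modest drift downward allowed, as a 1.4-fold lower number from compound 3 to compound 4 (0.15 log units; within the scatter). Compound 4 is estimated at 70000 nM, with a range from 25000 nM to 150000 nM.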

Compound 4, half-maximal cytotoxic concentration: 170000 nM
For compound 4 the middle estimate is 2.4-fold (0.39 log units) below the measured one, and the stated range ends below it.
By their numbers in this assay, from the lowest: compounds 2 and 1 (each within the scatter of the next); then compounds 3 and 4 (each within the scatter of the next).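

In this assay, the first step measured on the ester's carbonyl carbon is a 1.7-fold higher number from compound 3 to compound 4 (0.23 log units; within the scatter), which lies within the scatter. Compound 3 and compound 4 therefore cannot be told apart in this read-out, although pyridin-3-yl brings an aromatic ring where cyanomethyl has none and a nitrile is lost. At this place, the readings so far show tolerance of the exchange from an open group carrying a triple bond to a six-membered aromatic ring, and no measurement here explains why the two esters read alike.

Still open, on these data alone, is how an aminomethyl group, a plain phenyl ring or a longer alkyl chain would read on this carbonyl carbon. Among the compounds shown here, no single-place pair separates the ester from the free hydroxyl on the core of compound 3, so the contribution of the ester itself remains unknown.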